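The source may report more compounds than this note shows. Statements on the series, on what has been measured and on what is new or still open speak of the compounds shown alone.

Measured compounds:
compound 1 `CC(C(=O)NCc1ccc(C(C)(C)C)cc1N1CCN(c2ccccc2)CC1)c1ccc(NS(C)(=O)=O)c(F)c1` — in an assay on cells for antagonist activity at transient receptor potential cation channel subfamily V member 1 (Homo sapiens), read by FLIPR and calcium flux, with a stated time of 6 min (a higher number here means a weaker inhibitor, a lower number a stronger inhibitor), compound 1 gives 0.8 nM
compound 2 `CC(C(=O)NCc1ccc(C(C)(C)C)cc1OCc1ccc(F)cc1)c1ccc(NS(C)(=O)=O)c(F)c1` — in this assay compound 2 gives 3.8 nM

For the measured compounds named here, compound 2 holds the higher of the two numbers so far in this assay; its nearest neighbour is compound 1, and the gap is a 4.8-fold higher number from compound 1 to compound 2 (0.68 log units; beyond the scatter). The next member, compound 3 `CC(C(=O)NCc1ccc(C(C)(C)C)cc1C1CCCCC1)c1ccc(NS(C)(=O)=O)c(F)c1`, is not yet measured in this assay. The change from compound 2 is cyclohexyl in place of (4-fluorobenzyl)oxy on an aromatic carbon. Going by the values given here, only one measured step bears on this position, a 4.8-fold higher number from compound 1 to compound 2 (0.68 log units; beyond the scatter), which exchanged one substituent for another at the same aromatic carbon and moved the number modestly. Among the compounds with values here, neither measured compound carries a cyclohexyl or any non-aromatic ring at that site, so the direction of the present step is not fixed by the data; the one step available says that an exchange at this carbon shifts the number by a modest amount. The expectation for compound 3 is therefore a step of about a 1.8-fold higher number from compound 2 to compound 3 (0.27 log units; within the scatter), that is, a number near that of compound 2 or somewhat higher. The estimate for compound 3 in this assay is 7 nM, expected to fall between 1.8 nM and 28 nM.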

Compound 3, inhibition constant: 9.8 nM
Beside the measured number, compound 3's estimate is 1.4-fold (0.15 log units) below it; measured number inside the range.
By their numbers in this assay, from the lowest: compound 1; then compound 2; then compound 3.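

In this assay, for the compounds shown here, the exchange of (4-fluorobenzyl)oxy for cyclohexyl gives a 2.6-fold higher number from compound 2 to compound 3 (0.41 log units; beyond the scatter) and so supplies the first reading for a non-aromatic ring on this aromatic carbon, with the change lying beyond the scatter even though the step is modest. Set against 4-phenylpiperazin-1-yl, the same cyclohexyl gives a 12-fold higher number from compound 1 to compound 3 (1.09 log units; beyond the scatter) and this large step shows that the choice of substituent here can move the number by more than the earlier exchange did, with the three groups now ranking 4-phenylpiperazin-1-yl, (4-fluorobenzyl)oxy and cyclohexyl from lowest number to highest. Nothing at hand links these differences to any particular feature of the groups.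

With only three substituents compared, and all of them carrying a six-membered ring, the series cannot separate the contribution of the ring from that of the atoms joining it to the aromatic carbon. Open too, as far as these compounds go, is how a compact group without a ring, such as dimethylamino or methoxy, or a piperidin-1-yl or a carboxylic acid at this carbon, would place against these three.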